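Swapping a propyl for 3,4-difluorobenzyl on the sulfonyl

The source may hold more compounds than are shown below. What is called first, only, known or untested is meant among the compounds shown, and "the series" means these compounds.

compound 1: `CCCCSc1nnc(COc2cc(C)c3c(C)cc(=O)oc3c2)o1` — > 100000 nM
compound 2: `CCCCCSc1nnc(COc2cc(C)c3c(C)cc(=O)oc3c2)o1` — > 100000 nM
compound 3: `CCCS(=O)(=O)c1nnc(COc2cc(C)c3c(C)cc(=O)oc3c2)o1` — 7070 nM

In a functional assay on MDA-MB-231 cells (Homo sapiens) for antiproliferative activity, read by MTT assay, with a stated time of 24 h (a lower number here means a stronger inhibitor, a higher number a weaker inhibitor), compound 1 gives > 100000 nM, which is a limit of the assay and not a number. Compound 2 likewise gives > 100000 nM, again a limit. For the measured compounds named here, compound 3 gives 7070 nM, the only number among the three values shown, so compound 3 stands alone as the one compound with a readable result. The step that the two limits leave unreadable from compound 1 to compound 2 cannot be sized, because of the limit of > 100000 nM in this assay, at which 2 of the 3 values shown sit. By contrast the steps of an at least 14-fold lower number from compound 1 to compound 3 (1.15 log units; beyond the scatter) and an at least 14-fold lower number from compound 2 to compound 3 (1.15 log units; beyond the scatter) are large and point toward the sulfonyl.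

Compound 4 `Cc1cc(OCc2nnc(S(=O)(=O)Cc3ccc(F)c(F)c3)o2)cc2oc(=O)cc(C)c12` keeps that sulfonyl and differs from compound 3 in 3,4-difluorophenyl in place of ethyl on a saturated chain carbon bound to a sulfonyl sulfur. Going by the values given here, no measured step changes this part of the chain in a readable way, so the expectation rests on compound 3 alone; compound 4 is expected to sit near it, with a step of a 1.6-fold lower number from compound 3 to compound 4 (0.20 log units; within the scatter) that may stay within the scatter. The estimate for compound 4 is 4500 nM, with a range from 1000 nM to 20000 nM.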

Compound 4, half-maximal inhibitory concentration: 31600 nM
For compound 4 the middle estimate is 7.0-fold (0.85 log units) below the measured one; the whole stated range lies below it.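

In this assay, a 4.5-fold higher number from compound 3 to compound 4 (0.65 log units; beyond the scatter) shows that the value depends on what the sulfonyl carries, not on the sulfonyl alone. Propyl to 3,4-difluorobenzyl is the first change on a chain at this position that can be sized, and the larger group with its aromatic ring gives the weaker inhibitor of the pair. The earlier change of chain on the sulfur, from compound 1 to compound 2, cannot be read: the limit of > 100000 nM in this assay, at which 2 of the 4 values shown sit.

The compounds shown leave open whether an unsubstituted benzyl would stand with compound 3 or with compound 4, so the ring and its two fluorines cannot be separated here. They also leave open how a longer chain such as pentyl, or an amine at the end of the propyl, would read on the sulfonyl.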